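Methyl in place of hydrogen on the anilide ring

The source may hold more compounds than are shown below. What is called first, only, known or untested is meant among the compounds shown, and "the series" means these compounds.

The study measures a functional assay on the whole organism (strain albino) with Mus musculus as the target, at a dose of 100 mg/kg by the intraperitoneal route (on this read-out higher numbers stand for more inhibition at the one dose given (going by the name of the read-out) and lower numbers for less inhibition), across a small set of compounds sharing one core. Compound 1 `O=C(Nc1ccccc1)Nn1c(-c2ccccc2)nc2ccccc2c1=O` gives 56% in this assay. Compound 2 `CCc1nc2ccccc2c(=O)n1NC(=O)Nc1ccccc1` gives 54%, and compound 3 `Cc1ccccc1NC(=O)Nn1c(-c2ccccc2)nc2ccccc2c1=O` gives 59%. The step of a number 2 percentage points lower from compound 1 to compound 2 (within the scatter) lies within the scatter, as does a number 3 percentage points higher from compound 1 to compound 3 (within the scatter). Compound 2 holds the lowest of the three numbers, but both its neighbours sit within the scatter of it, so no order among the three can be claimed.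

Compound 4 `CCc1nc2ccccc2c(=O)n1NC(=O)Nc1cccc(C)c1` is not yet measured. It differs from compound 2 by methyl in place of hydrogen on an aromatic carbon

Going by the values given here, the only measured step that bears on this change is a number 3 percentage points higher from compound 1 to compound 3 (within the scatter), which also placed a methyl on an aromatic carbon of the anilide ring and stayed within the scatter. On that basis no shift beyond the scatter is expected for the step of a number 1 percentage points higher from compound 2 to compound 4 (within the scatter). Compound 4 is therefore estimated to give 55% in this assay, in a range from 44% to 66%.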

Compound 4, a percentage reported as inhibition, in the whole organism at one dose (the size of the read-out at that dose, not a potency): 53%
The estimate for compound 4 lay 2 percentage points above the measured number; the range from low to high includes it.
By their numbers in this assay, from the lowest: compounds 4, 2, 1 and 3 (each within the scatter of the next).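

With the ethyl group on the core, the change from phenyl to 3-methylphenyl, with the methyl meta to a large group, gives in this assay a step of a number 1 percentage points lower from compound 2 to compound 4 (within the scatter). Until now this change had been seen on one core only, and a methyl at this place on a second core also leaves the read-out within the scatter. Set side by side, the two steps cannot be told apart: the same change on two cores in this assay, a number 3 percentage points higher (within the scatter) from compound 1 to compound 3 and a number 1 percentage points lower (within the scatter) from compound 2 to compound 4, 4 percentage points apart, within the scatter of two such steps

All four compounds lie within the scatter of their neighbours, so the set does not yet show any group on this ring that separates one compound from another. On these data alone, whether a chlorine, a methoxy or a carboxylic acid in place of the methyl, or a longer chain in place of the ethyl, would shift the number beyond the scatter remains open.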